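The compounds below may be only part of what the source reports. "The series", "measured", "known", "first", "only" and "open" are said of these compounds alone.

In a functional assay for activation of Alpha-1D adrenergic receptor (Homo sapiens), read by calcium flux (on this read-out lower numbers stand for an effect already at smaller amounts and higher numbers for an effect only at larger amounts of compound), the three measured compounds stand as follows.

Compound 1, `c1ccc(-c2ccncc2)c(OCC2=NCCN2)c1`, gives < 100000 nM, which is a limit of the assay.
Compound 2, `c1cnc(-c2ccccc2OCC2=NCCN2)nc1`, gives < 100000 nM, which is a limit of the assay.
Compound 3, `c1ccc(-c2cnccn2)c(OCC2=NCCN2)c1`, gives < 100000 nM, again a limit of the assay and not a number.

Compound 3 therefore stands only at a limit, and the two further values shown are limits as well. The steps between the measured compounds cannot be sized: the step that the two limits leave unreadable from compound 1 to compound 2, the step that the two limits leave unreadable from compound 1 to compound 3 and the step that the two limits leave unreadable from compound 2 to compound 3 all remain unreadable, because of the limit of < 100000 nM in this assay, at which 3 of the 3 values shown sit.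

Compound 4, `c1ccc(-c2ccncn2)c(OCC2=NCCN2)c1`, differs from compound 3 by one change: pyrimidin-4-yl in place of pyrazin-2-yl on an aromatic carbon. The two have the same atoms, joined differently. All three measured steps bear on this change in that each swaps one six-membered aromatic ring with hetero atoms for another at the same place, and none of them yields a readable size. For compound 4 the step that the limit leaves unreadable from compound 3 to compound 4 is thus expected to lie within the unreadable region rather than to show any direction. Compound 4 is estimated at 50000 nM in this assay, with a range from 5000 nM to 100000 nM, most likely reported again as a limit.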

Compound 4, half-maximal effective concentration: < 100000 nM
Compound 4 gave a limit, no number (the forecaster's own chance of this, stated with the estimate: 85%); the middle value is on the limit's open side.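

Compound 4, like compound 1, compound 2 and compound 3, gives only a limit and not a number, so none of the steps among them can be read, because all four values rest on the same limit: the limit of < 100000 nM in this assay, at which 4 of the 4 values shown sit.

The four compounds leave open whether swapping these rings at this place makes any difference in this assay and how large such a difference would be.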